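Aryl amine variation on the shared core: bromo to nitro

This account rests on a few compounds, and the source may have more. Where it says the series, first, only, none or still open, it means among the compounds named here.

Compound 3 `FC(F)(F)c1ccc(CSc2nc(Nc3cccc(Br)c3)c3ccccc3n2)cc1` gives 22100 nM in a functional assay on MDA-MB-231 cells (Homo sapiens) for cytotoxicity, read by MTT assay, with a stated time of 72 h; a lower number here means a stronger inhibitor, a higher number a weaker inhibitor. Compound 1 `CCCCCCNc1nc(SCc2ccc(C(F)(F)F)cc2)nc2ccccc12` gives 20200 nM in this assay, and the step of a 1.1-fold higher number from compound 1 to compound 3 (0.04 log units; within the scatter) leaves the two indistinguishable. Compound 2 `CCOc1ccccc1Nc1nc(SCc2ccc(C(F)(F)F)cc2)nc2ccccc12` reaches only a limit in this assay, > 50000 nM (see (the limit of > 50000 nM in this assay, at which 1 of the 3 values shown sits)). Against that limit the step of an at least 2.4-fold higher number from compound 1 to compound 2 (0.39 log units; beyond the scatter) and the step of an at least 2.2-fold lower number from compound 2 to compound 3 (0.35 log units; beyond the scatter) are the only movements beyond the scatter among the three, so compound 3 stands with compound 1 at the lower end of the numbers, with compound 2 above both.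

Compound 4 `O=[N+]([O-])c1cccc(Nc2nc(SCc3ccc(C(F)(F)F)cc3)nc3ccccc23)c1` differs from compound 3 by nitro in place of bromo on an aromatic carbon. For the measured compounds named here, no measured step changes a substituent on the aryl amine while keeping the aryl; the steps that exist swap the whole group on the nitrogen, and those ran from within the scatter to at least modest. On that basis a step of a 1.1-fold higher number from compound 3 to compound 4 (0.05 log units; within the scatter) is expected, that is, no change beyond the scatter, with the limit remaining a possibility. Compound 4 is therefore estimated at 25000 nM in this assay, expected between 8000 nM and 60000 nM.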

Compound 4, half-maximal inhibitory concentration: 31500 nM
The estimate for compound 4 lay 1.3-fold (0.10 log units) below the measured number; low and high end bracket the measured number.
By their numbers in this assay, from the lowest: compounds 1, 3 and 4 (each within the scatter of the next). At a limit, above all of these: compound 2.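

Nitro in place of bromo is the first change shown that keeps the aryl on the nitrogen, and a 1.4-fold higher number from compound 3 to compound 4 (0.15 log units; within the scatter) means that this assay does not separate the two groups at this place on the ring. The comparison with the alkyl amine agrees, as a 1.6-fold higher number from compound 1 to compound 4 (0.19 log units; within the scatter) leaves 3-nitrophenyl and hexyl apart by no more than the scatter, so compounds 1, 3 and 4 carry no order among them. Compound 2 remains at a limit, and an at least 1.5-fold lower number from compound 2 to compound 4 (0.20 log units; that floor lies within the scatter) gives only a floor, so whether 3-nitrophenyl truly differs from 2-ethoxyphenyl cannot be read: the limit of > 50000 nM in this assay, at which 1 of the 4 values shown sits.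

The compounds shown leave open whether an amine or a carboxylic acid at this place would move the number beyond the scatter. On these data alone, the trifluoromethyl group is common to all four, so the effect of a nitrile in its stead also remains open.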